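A few compounds are considered here, and "the series" means these few. Any claim that something is new, unique, unknown or untested is made for them only; others in the source may bear on it.

Among the measured compounds shown here, compound 2 `O=C(COc1ccc2c(=O)ccoc2c1)Nc1cccc(NC(=O)c2ccccc2)c1` gives 120 nM in an assay on isolated protein for inhibition of Rho-associated protein kinase 1 (Homo sapiens), read by scintillation counting, radiometric assay and 33P incorporation, with a stated time of 40 min, in the presence of a further agent that is not named here (on this read-out lower numbers stand for stronger inhibition and higher numbers for weaker inhibition), the only number among the values shown. Compound 1 `CN(C)c1ccc(C(=O)Nc2cccc(NC(=O)COc3ccc4c(c3)CCC(=O)N4)c2)cc1` returns only a limit, > 10000 nM, and the limit of > 10000 nM in this assay, at which 1 of the 2 values shown sits, is where that value sits. Compound 3 `Cc1cc(C(=O)Nc2cccc(NC(=O)COc3ccc4c(=O)ccoc4c3)c2)no1` is not yet measured; it differs from compound 2 by 5-methyl-1,2-oxazol-3-yl in place of phenyl on a carbonyl carbon. No step between measured compounds is shown, so only a modest shift, if any beyond the scatter, is expected in this assay, and the expected step is a 1.7-fold higher number from compound 2 to compound 3 (0.22 log units; within the scatter). Compound 3 is therefore estimated at 200 nM, within a range from 60 nM to 700 nM.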

Compound 3, half-maximal inhibitory concentration: 68 nM
Estimate against measurement, compound 3: 2.9-fold (0.47 log units) above, within the range that was stated.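

In this assay, putting 5-methyl-1,2-oxazol-3-yl in place of phenyl on a carbonyl carbon gives a 1.8-fold lower number from compound 2 to compound 3 (0.25 log units; within the scatter). This position therefore takes a five-membered aromatic ring with 2 hetero atoms, and with it 2 hydrogen-bond acceptors, with no change that can be told from scatter. Nothing shown bears on the reason for this step. As far as these compounds go, it remains open whether an amine or a carboxylic acid on this carbonyl carbon would hold the value, and what share of the step belongs to the methyl group.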